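The source may report more compounds than this note shows. Statements on the series, on what has been measured and on what is new or still open speak of the compounds shown alone.

Of the compounds shown here, three built on one shared core have so far been measured in an assay on isolated protein for inhibition of histone deacetylase 8 (Homo sapiens), with a stated time of 1 h; a lower number here means a stronger inhibitor, a higher number a weaker inhibitor. Compound 1 `Cc1ccc(NC(=O)COc2ccc3cc(/C=C4/SC(=O)NC4=O)ccc3c2)cc1` gives 9000 nM. Compound 3 `Cc1cccc2sc(NC(=O)COc3ccc4cc(/C=C5/SC(=O)NC5=O)ccc4c3)nc12` gives 5800 nM, the lowest of the two numbers, with compound 1 as its nearest neighbour, and the step of a 1.6-fold lower number from compound 1 to compound 3 (0.19 log units; within the scatter) lies within the scatter. For compound 2 `O=C(COc1ccc2cc(/C=C3/SC(=O)NC3=O)ccc2c1)Nc1cc(Cl)cc(C(F)(F)F)c1` the assay reports only a limit, > 50000 nM. The step of an at least 5.5-fold higher number from compound 1 to compound 2 (0.74 log units; beyond the scatter) and the step of an at least 8.6-fold lower number from compound 2 to compound 3 (0.93 log units; beyond the scatter) both set the 3-chloro-5-(trifluoromethyl)phenyl apart from the other two groups on the amide-type nitrogen.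

Compound 4 `O=C(COc1ccc2cc(/C=C3/SC(=O)NC3=O)ccc2c1)Nc1ccc(Br)c(Br)c1` has not yet been measured. It differs from compound 3 in one place: 3,4-dibromophenyl in place of 4-methyl-1,3-benzothiazol-2-yl on an amide-type nitrogen. A 3,4-dibromophenyl resembles the 3-chloro-5-(trifluoromethyl)phenyl of compound 2 more closely than the 4-methylphenyl of compound 1 or the 4-methyl-1,3-benzothiazol-2-yl of compound 3, so the steps of an at least 5.5-fold higher number from compound 1 to compound 2 (0.74 log units; beyond the scatter) and an at least 8.6-fold lower number from compound 2 to compound 3 (0.93 log units; beyond the scatter) point towards a weaker inhibitor, possibly again only a limit. Compound 4 is therefore expected to give about 20000 nM, between 6000 nM and 60000 nM. That estimate means an expected step of a 3.4-fold higher number from compound 3 to compound 4 (0.54 log units; beyond the scatter).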

Compound 4, half-maximal inhibitory concentration: > 50000 nM
Compound 4: only a limit was reported (the forecaster's own chance of this, stated with the estimate: 35%); middle value at least 2.5-fold (0.39 log units) from the limit.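

In this assay compound 4 is again reported only as a limit of the assay, > 50000 nM. With an at least 8.6-fold higher number from compound 3 to compound 4 (0.93 log units; beyond the scatter) and an at least 5.5-fold higher number from compound 1 to compound 4 (0.74 log units; beyond the scatter), a second halogen-bearing phenyl on the amide-type nitrogen separates from the 4-methylphenyl and the 4-methyl-1,3-benzothiazol-2-yl, so the loss seen with compound 2 does not need a trifluoromethyl group, which compound 4 lacks. The steps between compound 2 and compound 4 cannot be read, since the two share one limit and any order between them stays hidden: the limit of > 50000 nM in this assay, at which 2 of the 4 values shown sit.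

Going by these compounds, it remains open how far past the limit either compound lies. On these data alone, it is also open whether a single halogen, as in a 4-bromophenyl, already brings this loss, and how a phenyl carrying a carboxylic acid or an amine would behave at this nitrogen.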